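A few compounds are considered here, and "the series" means these few. Any claim that something is new, unique, unknown or untested is made for them only; others in the source may bear on it.

Going by the values given here, compound 1 `O=C1/C(=C\c2ccccc2)c2c(ncn2COCc2ccccc2)CCN1Cc1ccccc1` has the lower of the two numbers measured so far: in a functional assay on A549 cells (Homo sapiens) for inhibition, read by MTT assay, with a stated time of 72 h (a lower number here means a stronger inhibitor, a higher number a weaker inhibitor), compound 1 gives 9900 nM, while compound 2 `O=C1/C(=C\c2ccccc2)c2c(ncn2COCc2ccccc2)CCN1Cc1ccc(Cl)cc1` gives 11800 nM, a gap that stays within the scatter. Among the compounds with values here, the only measured step, a 1.2-fold higher number from compound 1 to compound 2 (0.08 log units; within the scatter), alters a different ring from the one changed here, so it guides only loosely. Compound 3 `O=C1/C(=C\c2ccc(C(F)(F)F)cc2)c2c(ncn2COCc2ccccc2)CCN1Cc1ccccc1` differs from compound 1 by trifluoromethyl in place of hydrogen on an aromatic carbon. With nothing but a within-scatter step on another ring to lean on, no shift beyond the scatter is expected. The estimated value for compound 3 in this assay is 10000 nM, with a range from 4000 nM to 25000 nM. This expected result means a step of a 1.0-fold higher number from compound 1 to compound 3 (0.00 log units; within the scatter).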

Compound 3, half-maximal inhibitory concentration: 52500 nM
Beside the measured number, compound 3's estimate is 5.3-fold (0.72 log units) below it; the measured number lies above the stated range.
By their numbers in this assay, from the lowest: compounds 1 and 2 (each within the scatter of the next); then compound 3.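

In this assay, placing trifluoromethyl on this phenyl ring gives a 5.3-fold higher number from compound 1 to compound 3 (0.72 log units; beyond the scatter), so compound 3 is a weaker inhibitor. Going by these compounds alone, this shows that the position is not indifferent to substitution, even though the one earlier step, made on a different ring, stayed within the scatter. Nothing available explains this loss of inhibition. On these data alone, whether a methoxy group, an amine or a carboxylic acid at this position would also raise the number remains open. So does whether chloro, which left the number within the scatter on the other ring, would behave the same way here.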